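The source may report more compounds than this note shows. Statements on the series, on what has been measured and on what is new or still open speak of the compounds shown alone.

Compounds measured so far:
compound 1, `O=S(=O)(c1ccccc1)c1nc2ccccc2nc1Nc1ccc(Cl)cc1`, 15300 nM in a functional assay on PC-3 cells (Homo sapiens) for cytotoxicity, read by MTT assay, with a stated time of 72 h; a lower number here means a stronger inhibitor, a higher number a weaker inhibitor
compound 2, `Cc1ccc(S(=O)(=O)c2nc3ccccc3nc2Nc2ccc(Cl)cc2)cc1`, 9660 nM
compound 3, `COc1ccc(Nc2nc3ccccc3nc2S(=O)(=O)c2ccc(Br)cc2)cc1`, 1110 nM

All three share one core and differ only in the groups hung on its two outer rings. Compound 3 stands lowest of the three numbers, that is, as the strongest inhibitor here: the nearest to it is compound 2, whose number is higher by more than the usual scatter, and compound 1 lies further still. The step from compound 1 to compound 2, a 1.6-fold lower number from compound 1 to compound 2 (0.20 log units; within the scatter), concerns the ring that carries the sulfonyl group and shows that a methyl there changes little.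

Compound 4, `O=S(=O)(c1ccc(Br)cc1)c1nc2ccccc2nc1Nc1ccc(Cl)cc1`, has not yet been measured. It is compound 3 with one change: chloro in place of methoxy on an aromatic carbon. Compound 4 therefore carries the same (4-chlorophenyl)amino group as compounds 1 and 2, while keeping the bromo group of compound 3 on the other ring. Among the compounds with values here, no measured step alters this group alone, so the direct effect of the change is unknown. Compounds 1 and 2 show that the (4-chlorophenyl)amino group can go with weak inhibition, but they also lack the bromo group of compound 3, so the two effects cannot be separated. Compound 4 is expected to give 4000 nM, a step of a 3.6-fold higher number from compound 3 to compound 4 (0.56 log units; beyond the scatter) from compound 3 toward weaker inhibition. The estimate for compound 4 spans from 1200 nM to 13000 nM.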

Compound 4, half-maximal inhibitory concentration: 7460 nM
For compound 4 the middle estimate is 1.9-fold (0.27 log units) below the measured one; the measured number falls inside the stated range.
By their numbers in this assay, from the lowest: compound 3; then compounds 4, 2 and 1 (each within the scatter of the next, the first and the last beyond it).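

In this assay, within the data shown here, the step of a 6.7-fold higher number from compound 3 to compound 4 (0.83 log units; beyond the scatter) gives the first direct reading of this position with the bromo group on the other ring held fixed: changing (4-methoxyphenyl)amino to (4-chlorophenyl)amino is enough on its own to move the number beyond the scatter, so the bromo group alone does not bring the low number seen with the methoxy group. With the (4-chlorophenyl)amino group held fixed, the new data also separate the contribution of the other ring, where bromo in place of methyl gives a 1.3-fold lower number from compound 2 to compound 4 (0.11 log units; within the scatter) and bromo in place of hydrogen gives a 2.1-fold lower number from compound 1 to compound 4 (0.31 log units; beyond the scatter), a modest step. Nothing measured here bears on the reason for the shift at the methoxy position.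

On these data alone, only methoxy and chloro are compared at this position, so it remains open how a hydroxyl group, an amine or a longer chain such as ethoxy would behave there. As far as these compounds go, it also remains open whether methoxy would lower the number to the same extent with hydrogen or methyl in place of the bromo group.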